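The source may report more compounds than this note shows. Statements on the series, on what has been measured and on what is new or still open speak of the compounds shown alone.

Compound 1 `c1ccc2c(c1)CCC2CCN1CCN(c2cccc3c2OCCO3)CC1`: 417 nM
Compound 2 `c1ccc2c(c1)CC(CCCN1CCN(c3cccc4c3OCCO4)CC1)C2`: 1860 nM
Compound 3 `Clc1cccc2c1CC2CN1CCN(c2cccc3c2OCCO3)CC1`: 550 nM

In an assay on isolated protein for binding affinity to 5-hydroxytryptamine receptor 1B (Rattus norvegicus) (a lower number here means a stronger inhibitor, a higher number a weaker inhibitor), compound 1 gives the lowest of the three numbers; compound 3 lies within the usual scatter of it, while compound 2 stands beyond the scatter with a clearly higher number. Compound 4 `Clc1cccc2c1CC2CCN1CCN(c2cccc3c2OCCO3)CC1` has not yet been measured in this assay. It differs from compound 1 in one place: a group of 9 heavy atoms (8 carbon, 1 chlorine; one four-membered non-aromatic ring of carbon only, one six-membered aromatic ring of carbon only) in place of a group of 9 heavy atoms (9 carbon; one five-membered non-aromatic ring of carbon only, one six-membered aromatic ring of carbon only), on a saturated chain carbon, two bonds along the chain from an amine nitrogen in a ring. Within the data shown here, no measured pair shows this change directly, so its size is open. Since compound 3 in this assay gives 550 nM, a number within the scatter of compound 1, a value in the same region is expected for compound 4, with no step beyond the scatter in either direction. Compound 4 is therefore estimated at 400 nM, with a range from 150 nM to 1200 nM. This estimate means an expected step of a 1.0-fold lower number from compound 1 to compound 4 (0.02 log units; within the scatter).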

Compound 4, inhibition constant: 708 nM
Beside the measured number, compound 4's estimate is 1.8-fold (0.25 log units) below it; the range from low to high includes it.
By their numbers in this assay, from the lowest: compounds 1, 3 and 4 (each within the scatter of the next); then compound 2.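

In this assay, among these compounds, putting the chlorine-bearing group with its four-membered ring in place of 2,3-dihydro-1H-inden-1-yl gives a 1.7-fold higher number from compound 1 to compound 4 (0.23 log units; within the scatter) as the first direct reading of a change at this position. On this saturated chain carbon, two bonds along the chain from an amine nitrogen in a ring, the two groups therefore cannot be told apart in this assay. Ring size and chlorine change together here, so their separate contributions stay open, as does the result of fluorine or methoxy in place of the chlorine. Nothing measured here explains this result.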